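This account rests on a few compounds, and the source may have more. Where it says the series, first, only, none or still open, it means among the compounds named here.

Measured compounds so far:
- Compound 1, `COCOc1cc(O)ccc1/C=C/C(=O)c1ccc(O)cc1O`: in a functional assay on A375-C5 cells (Homo sapiens) for inhibition, read by sulforhodamine B assay, with a stated time of 48 h (on this read-out lower numbers stand for stronger inhibition of growth and higher numbers for weaker inhibition of growth), compound 1 gives "not determined" (no result reported).
- Compound 2, `COc1ccc(/C=C/C(=O)c2ccc(O)cc2O)c(OC)c1`: in this assay compound 2 gives 30300 nM.

Going by the values given here, compound 2 thus carries the only number in this assay; compound 1 has no number, so nothing can be said about how the two compare. Against that single figure stands compound 3, `COc1cc(OC)c(OC)cc1/C=C/C(=O)c1ccc(O)cc1O`, which differs from compound 2 by methoxy in place of hydrogen on an aromatic carbon. Among the compounds with values here, no step between two measured compounds exists here, so there is no measured precedent for what this change does. With only one data point, the expectation has to stay close to it. The step from compound 2 to compound 3 is estimated as a 1.5-fold lower number from compound 2 to compound 3 (0.18 log units; within the scatter), which is expected to lie at most around the edge of the usual scatter. Compound 3 is therefore expected to give about 20000 nM, with a plausible range from 6000 nM to 65000 nM.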

Compound 3, concentration for 50% growth inhibition: 34800 nM
The estimate for compound 3 lay 1.7-fold (0.24 log units) below the measured number, and the stated range covers the measured number.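

In this assay, putting methoxy in place of hydrogen on this aromatic carbon, which is ortho to a methoxy group and para to a methoxy group, gives a 1.1-fold higher number from compound 2 to compound 3 (0.06 log units; within the scatter). Going by these compounds alone, this is the first measured step at this position, and it shows that the extra methoxy group can sit there with no difference that stands out from the normal spread of repeated measurements. No measurement shown here offers an explanation for this result.

As far as these compounds go, whether an amine, a carboxylic acid or a longer chain such as butoxy on this same carbon would give a clearly different number remains open. From the compounds shown here alone, it is also open whether methoxy would behave the same way on a ring without the two methoxy groups already present.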